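The source may hold more compounds than are shown below. What is called first, only, known or untested is meant among the compounds shown, and "the series" means these compounds.

Three compounds share one core and differ only in the group attached to the sulfonyl sulfur. Compound 1 `CCCCCCCCCCCCS(=O)(=O)/C=C/c1ccc(O)c(O)c1` carries a dodecyl chain, compound 3 `CCCCCCCS(=O)(=O)/C=C/c1ccc(O)c(O)c1` a heptyl chain, and compound 2 `O=S(=O)(/C=C/c1ccc(O)c(O)c1)CC1CCCO1` an oxolan-2-yl on the saturated chain carbon bound to a sulfonyl sulfur. In a functional assay, read by fluorescence and spectrophotometry, with a stated time of 1 h (on this read-out higher numbers stand for an effect only at larger amounts of compound and lower numbers for an effect already at smaller amounts), compound 1 gives 8500 nM, compound 3 gives 7100 nM and compound 2 gives 10500 nM. Compound 1 therefore stands in the middle of the three, and all three numbers lie within the usual scatter of one another: the shortening of the chain gives a 1.2-fold lower number from compound 1 to compound 3 (0.08 log units; within the scatter), and the exchange at the sulfur-bound carbon gives a 1.5-fold lower number from compound 2 to compound 3 (0.17 log units; within the scatter).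

Compound 4 `C=CCCCCCS(=O)(=O)/C=C/c1ccc(O)c(O)c1` is the next compound. It differs from compound 1 as follows: vinyl in place of heptyl on a saturated chain carbon, five bonds along the chain from a sulfonyl sulfur. Among the measured compounds shown here, the step that bears most on it is the one from compound 1 to compound 3, which also shortened the chain and changed nothing beyond the scatter; the step from compound 2 to compound 3 shows that a quite different group on the chain also stayed within the scatter. Compound 4 is thus expected to show a 1.1-fold lower number from compound 1 to compound 4 (0.05 log units; within the scatter), that is, no change beyond the scatter. The estimate for compound 4 in this assay is 7500 nM, with a range from 4000 nM to 15000 nM.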

Compound 4, half-maximal effective concentration: 7100 nM
Compound 4: middle estimate off by 1.1-fold (0.02 log units), on the high side; low and high end bracket the measured number.
By their numbers in this assay, from the lowest: compounds 3, 4, 1 and 2 (each within the scatter of the next).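

In this assay, a chain ending in vinyl, with one double bond outside aromatic rings, sits on the sulfonyl sulfur without any step leaving the scatter. Vinyl in place of heptyl gives a 1.2-fold lower number from compound 1 to compound 4 (0.08 log units; within the scatter) and vinyl in place of ethyl, the exchange that touches only the end of the chain, gives no change at the digits printed from compound 3 to compound 4 (within the scatter) so that, among these compounds, the saturated end of the chain and the double bond cannot be told apart at the place five bonds along the chain from a sulfonyl sulfur. Hex-5-en-1-yl in place of oxolan-2-yl on the saturated chain carbon bound to a sulfonyl sulfur gives a 1.5-fold lower number from compound 2 to compound 4 (0.17 log units; within the scatter) and so also stays within the scatter, while nothing available bears on why these numbers lie so close together.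

What the compounds shown leave open is whether an amine or a carboxylic acid at the end of the chain, five bonds along the chain from a sulfonyl sulfur, would also stay within the scatter. All four compounds share one core, so they also leave open how the numbers respond to any exchange on that core.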